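Fluoro to trifluoromethyl on two urea-linked pyrazole series

A few compounds are considered here, and "the series" means these few. Any claim that something is new, unique, unknown or untested is made for them only; others in the source may bear on it.

Measured compounds:
Compound 1 `Cn1ncc2c(NC(=O)NCc3cc(C(F)(F)F)nn3-c3cccc(F)c3)cccc21`: 7 nM
Compound 2 `Cn1ncc2c(NC(=O)NCc3cc(C(F)(F)F)nn3-c3cccc(C(F)(F)F)c3)cccc21`: 1.4 nM
Compound 3 `CC(C)(C)c1cc(CNC(=O)Nc2cccc3[nH]ncc23)n(-c2cccc(F)c2)n1`: 1.3 nM

In an assay on CHO-K1 cells for antagonist activity at transient receptor potential cation channel subfamily V member 1 (Homo sapiens), read by FLIPR and calcium flux, with a stated time of 6 min (on this read-out lower numbers stand for stronger inhibition and higher numbers for weaker inhibition), compound 1 gives 7 nM. Compound 2 differs from it by one change, (trifluoromethyl in place of fluoro on an aromatic carbon), and in this assay compound 2 gives 1.4 nM, so that a 5.0-fold lower number from compound 1 to compound 2 (0.70 log units; beyond the scatter). Compound 3 carries a different core; the difference between the two cores is not broken down here. In this assay compound 3 gives 1.3 nM, a number that lies within the scatter of compound 2 and well apart from compound 1.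

Compound 4 `CC(C)(C)c1cc(CNC(=O)Nc2cccc3[nH]ncc23)n(-c2cccc(C(F)(F)F)c2)n1` has not yet been measured. It differs from compound 3 by trifluoromethyl in place of fluoro on an aromatic carbon, the same change already seen in going from compound 1 to compound 2, at the same place. For the measured compounds named here, because a 5.0-fold lower number from compound 1 to compound 2 (0.70 log units; beyond the scatter), a lower number is expected for compound 4 as well, though the single earlier example makes the size uncertain. Compound 4 is expected to give about 0.4 nM, with the range 0.12 nM to 1.3 nM, which would mean an estimated 3.3-fold lower number from compound 3 to compound 4 (0.51 log units; beyond the scatter).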

Compound 4, inhibition constant: 0.3 nM
Beside the measured number, compound 4's estimate is 1.3-fold (0.12 log units) above it, and the stated range covers the measured number.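

In this assay, trifluoromethyl in place of fluoro on the aromatic carbon gives a 4.3-fold lower number from compound 3 to compound 4 (0.64 log units; beyond the scatter), so the second core shows a step in the same direction as the first. Set side by side, the two steps do not differ in size beyond what repeated measurements would allow: the same change on two cores in this assay, a 5.0-fold lower number (0.70 log units; beyond the scatter) from compound 1 to compound 2 and a 4.3-fold lower number (0.64 log units; beyond the scatter) from compound 3 to compound 4, 1.2-fold (0.06 log units) apart, within the scatter of two such steps This shows that the change carried over between these two cores in this one assay, but two steps cannot show that it would carry over to a further core, and they give no reason for the lower numbers.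

The compounds shown leave open whether a chloro, methoxy or nitrile group on the same aromatic carbon would give a similar step. They also leave open which part of the difference between the two cores, if any, bears on the step, and whether it would hold on a core carrying an amine or a carboxylic acid.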